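Swapping an aminomethyl group for an amide on an isoxazole

This account rests on a few compounds, and the source may have more. Where it says the series, first, only, none or still open, it means among the compounds named here.

Compound 1 `CCNC(=O)c1noc(-c2cc(C(C)C)c(O)cc2O)c1-c1cc(COCC(=O)O)no1`: "not determined" (no result reported)
Compound 2 `CCNC(=O)c1noc(-c2cc(C(C)C)c(O)cc2O)c1-c1cc(CNC)no1`: "not determined" (no result reported)
Compound 3 `CCNC(=O)c1noc(-c2cc(C(C)C)c(O)cc2O)c1-c1cc(CN(CC)CC)no1`: 78 nM

Three compounds share one core and differ only in the group on the outer five-membered ring. In a functional assay on A2780 cells (Homo sapiens) for inhibition (on this read-out lower numbers stand for stronger inhibition and higher numbers for weaker inhibition), compound 3 gives 78 nM, while compound 1 gives "not determined" (no result reported) and compound 2 gives "not determined" (no result reported). Compound 2 therefore stands without a value of its own, and one further entry is likewise without a number; compound 3 is the only anchor.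

Compound 4 `CCNC(=O)c1noc(-c2cc(C(C)C)c(O)cc2O)c1-c1cc(C(N)=O)no1` carries the change (carbamoyl in place of (methylamino)methyl on an aromatic carbon). Within the data shown here, no pair of measured compounds shows how such a change shifts the read-out, so no direction can be stated; without an anchor for compound 2, any step in this assay is left open.

Compound 4 is estimated at about 120 nM, expected between 25 nM and 600 nM.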

Compound 4, half-maximal inhibitory concentration: 15 nM
Compound 4: the middle estimate sits 8.0-fold (0.90 log units) above what was measured, outside the stated range (below it).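

In this assay, carbamoyl in place of (diethylamino)methyl gives a 5.2-fold lower number from compound 3 to compound 4 (0.72 log units; beyond the scatter), so the read-out does respond to the group at this position of the outer ring. The step from compound 2 to compound 4 cannot be read, as compound 2 has no number. Nothing measured here explains the shift.

As far as these compounds go, whether the amide hydrogens matter stays open, and a methyl amide or a carboxylic acid placed directly on the ring would speak to that. A smaller amine such as aminomethyl would show whether the size of the amine counts.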